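A few compounds are considered here, and "the series" means these few. Any claim that something is new, unique, unknown or untested is made for them only; others in the source may bear on it.

Measured compounds:
Compound 1, `COc1cc2c(Oc3ccc(NC(=O)c4cn(-c5ccc(Cl)cc5)cn4)cc3F)ccnc2cc1OCCCN1CCN(C)CC1`: 4110 nM
Compound 2, `COc1cc2c(Oc3ccc(NC(=O)c4cn(-c5ccccc5OC)cn4)cc3F)ccnc2cc1OCCCN1CCCCC1`: 260 nM
Compound 3, `COc1cc2c(Oc3ccc(NC(=O)c4cn(-c5ccccc5OC(F)(F)F)cn4)cc3F)ccnc2cc1OCCCN1CCCCC1`: 190 nM

All three were tested in a functional assay on MKN-45 cells (Homo sapiens) for cytotoxicity, read by MTT assay, with a stated time of 72 h; a higher number here means a weaker inhibitor, a lower number a stronger inhibitor. On these numbers compound 2 stands second highest of the three. Its nearest neighbour is compound 3, with a 1.4-fold lower number from compound 2 to compound 3 (0.14 log units; within the scatter), a change of trifluoromethyl in place of methyl on an oxygen on an aromatic ring. Its furthest neighbour is compound 1, whose number is far higher; compound 1 differs from compound 2 in two places at once, so its value cannot be tied to either change alone.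

Compound 4, `COc1cc2c(Oc3ccc(NC(=O)c4cn(-c5ccc(Cl)cc5Cl)cn4)cc3F)ccnc2cc1OCCCN1CCCCC1`, has not yet been measured in this assay. It differs from compound 2 in one place: 2,4-dichlorophenyl in place of 2-methoxyphenyl on an aromatic nitrogen. Among the compounds with values here, the only single-step comparison at hand, from compound 2 to compound 3, lies within the scatter, and it concerns a different group at the same place. The gap between compound 1 and compound 2 points toward a higher number with a chlorine-bearing phenyl, but the second difference between those two compounds leaves that reading uncertain.

Compound 4 is therefore expected to give 400 nM, between 150 nM and 1500 nM, which means an expected step of a 1.5-fold higher number from compound 2 to compound 4 (0.19 log units; within the scatter).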

Compound 4, half-maximal inhibitory concentration: 6240 nM
For compound 4 the middle estimate is 16-fold (1.19 log units) below the measured one; the whole stated range lies below it.
By their numbers in this assay, from the lowest: compounds 3 and 2 (each within the scatter of the next); then compounds 1 and 4 (each within the scatter of the next).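

On the aromatic nitrogen of the five-membered ring, the choice of group matters far more than the earlier pair suggested: in this assay, putting 2,4-dichlorophenyl in place of 2-methoxyphenyl gives a 24-fold higher number from compound 2 to compound 4 (1.38 log units; beyond the scatter), and putting it in place of 2-(trifluoromethoxy)phenyl gives a 33-fold higher number from compound 3 to compound 4 (1.52 log units; beyond the scatter). The number of heavy atoms does not separate these groups, since 2-methoxyphenyl and 2,4-dichlorophenyl have the same count; what differs is that two chlorines enter, and the oxygen, a hydrogen-bond acceptor, leaves. Nothing available here measures why this swap has so large an effect.

Because 2,4-dichlorophenyl differs from the other groups in more than one respect, the compounds shown do not tell whether one chlorine, both chlorines or the loss of the oxygen drives the step, and compound 1 cannot settle this because it also differs in a second place. From the compounds shown here alone, it also remains open how this position would respond to an unsubstituted phenyl, or to a phenyl carrying an amine or a carboxylic acid.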